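A few compounds are considered here, and "the series" means these few. Any claim that something is new, unique, unknown or untested is made for them only; others in the source may bear on it.

Working notes on the series.

Three compounds of the shared core have been run in an assay on isolated protein (Cavia porcellus) with Sigma non-opioid intracellular receptor 1 (Homo sapiens) as the target, read by radioligand binding; on this read-out lower numbers stand for stronger inhibition and higher numbers for weaker inhibition. Compound 1 `CN(C)CCCCCCCCCCOc1ccc2oc(-c3ccccc3)cc(=O)c2c1` gives 341 nM, compound 2 `O=c1cc(-c2ccccc2)oc2ccc(OCCCCCCN3CCCCC3)cc12` gives 54 nM, and compound 3 `O=c1cc(-c2ccccc2)oc2ccc(OCCCCCCN3CCNC(CCO)C3)cc12` gives 94 nM. Compound 3 thus stands second highest of the three numbers: the gap to compound 2 is within the scatter, while the step of a 3.6-fold lower number from compound 1 to compound 3 (0.56 log units; beyond the scatter) is beyond it, as is a 6.3-fold lower number from compound 1 to compound 2 (0.80 log units; beyond the scatter).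

Compound 4 `CCOC(=O)C1CCN(CCCCCCOc2ccc3oc(-c4ccccc4)cc(=O)c3c2)CC1` differs from compound 3 in one place: 4-(ethoxycarbonyl)piperidin-1-yl in place of 3-(2-hydroxyethyl)piperazin-1-yl on a saturated chain carbon, six bonds along the chain from an oxygen on an aromatic ring. Within the data shown here, the steps that bear on this change are those at the same position, a 1.7-fold higher number from compound 2 to compound 3 (0.24 log units; within the scatter) and a 3.6-fold lower number from compound 1 to compound 3 (0.56 log units; beyond the scatter). Both ring amines gave numbers within the scatter of each other, and only the open 4-(dimethylamino)butyl end stood apart. A further ring amine at this position is therefore expected to land in this assay close to compounds 2 and 3, with no step beyond the scatter expected from compound 3: a 1.4-fold lower number from compound 3 to compound 4 (0.16 log units; within the scatter). Compound 4 is estimated at 65 nM, with a range from 20 nM to 200 nM.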

Compound 4, half-maximal inhibitory concentration: 102 nM
Beside the measured number, compound 4's estimate is 1.6-fold (0.20 log units) below it; the measured number falls inside the stated range.
By their numbers in this assay, from the lowest: compounds 2, 3 and 4 (each within the scatter of the next); then compound 1.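

At this position, this assay does not separate 4-(ethoxycarbonyl)piperidin-1-yl from 3-(2-hydroxyethyl)piperazin-1-yl (a 1.1-fold higher number from compound 3 to compound 4 (0.04 log units; within the scatter)), although the entering group has 0 hydrogen-bond donors and the leaving group has 2, so a number in this range does not depend on those donors. Ethoxycarbonyl in place of hydrogen on a saturated ring carbon also stays within the scatter (a 1.9-fold higher number from compound 2 to compound 4 (0.28 log units; within the scatter)), while a third ring amine stands apart from the open 4-(dimethylamino)butyl end (a 3.3-fold lower number from compound 1 to compound 4 (0.52 log units; beyond the scatter)). No supporting measurement bears on this result.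

On these data alone, whether a carboxylic acid or an amide in place of the ethyl ester would stay with compound 4 remains open. So does the effect of a morpholine ring at the chain end, or of a shorter or longer chain carrying the piperidin-1-yl group.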